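Compound 1 to compound 4: bromo in place of iodo

A few compounds are considered here, and "the series" means these few. Any claim that something is new, unique, unknown or untested is made for them only; others in the source may bear on it.

In a functional assay on MOLT-4 cells (Homo sapiens) for inhibition (a lower number here means a stronger inhibitor, a higher number a weaker inhibitor), compound 1 (`O=C1O/C(=C\Cn2cc(I)c(=O)[nH]c2=O)C(OCc2ccccc2)=C1OCc1ccccc1`) gives 3900 nM as its half-maximal inhibitory concentration, and compound 3 (`O=C1O/C(=C\Cn2cnc3c(-n4cccc4)ncnc32)C(OCc2ccccc2)=C1OCc1ccccc1`) gives the same number, 3900 nM at the digits shown. Compound 2 (`O=C1O/C(=C\Cn2ccc(=O)[nH]c2=O)C(OCc2ccccc2)=C1OCc1ccccc1`) gives 4800 nM in the same read-out. Compound 1 therefore stands level with compound 3, and compound 2 lies within the scatter of compound 1.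

Compound 4 (`O=C1O/C(=C\Cn2cc(Br)c(=O)[nH]c2=O)C(OCc2ccccc2)=C1OCc1ccccc1`) has not been measured. It keeps the core of compound 1 and carries one change (bromo in place of iodo on an aromatic carbon), bromo in place of iodo on an aromatic carbon.

Going by the values given here, one measured step bears on this change, at the same aromatic carbon. Hydrogen in place of iodo gives a 1.2-fold higher number from compound 1 to compound 2 (0.09 log units; within the scatter) and is the only evidence on this position. Among the compounds with values here, no step links compound 3 to compound 1, so it adds nothing here, and no bromo compound has a measured value yet. Within the data shown here, with only that small step to go on, no step beyond the scatter is expected in this assay in either direction. The expected step is a 1.1-fold higher number from compound 1 to compound 4 (0.03 log units; within the scatter) and remains an estimate. Compound 4 is estimated at 4200 nM with 2200 nM to 8000 nM as its expected range.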

Compound 4, half-maximal inhibitory concentration: 3900 nM
The estimate for compound 4 lay 1.1-fold (0.03 log units) above the measured number; measured number inside the range.
By their numbers in this assay, from the lowest: compounds 1, 3, 4 and 2 (each within the scatter of the next).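

In this assay, the aromatic carbon that carries iodo in compound 1 now has a second halogen on record, and bromo in place of iodo gives a flat step (no change at the digits printed from compound 1 to compound 4 (within the scatter)). Against the unsubstituted carbon, bromo in place of hydrogen gives a step of the same kind (a 1.2-fold lower number from compound 2 to compound 4 (0.09 log units; within the scatter)), so iodo, bromo and hydrogen at this carbon all lie within the scatter of one another and this read-out separates none of the three. No supporting measurement is available to explain why this position is so flat.

Still open, on these data alone, is whether a group of a different kind at this carbon, such as an amine, a carboxylic acid or a longer chain, would move the number beyond the scatter. Also open, as far as these compounds go, is whether the same flat picture at this carbon would hold with a change elsewhere on the shared core, since all three compounds compared here carry that core unchanged.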